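The compounds below may be only part of what the source reports. "The series", "measured", "known", "first", "only" and "open" are said of these compounds alone.

Working notes on the series. Compound 1 `Nc1ncnc2c1ncn2/C=C1\C[C@@H]1[C@H](O)CO` is the parent of this pair of nucleoside-like compounds; in an ADME assay on HFF cells (Homo sapiens) for cytotoxicity, read by neutral red uptake (on this read-out lower numbers stand for higher toxicity in this test and higher numbers for lower toxicity in this test), compound 1 returns only a limit, > 300000 nM, and not a number. Compound 2 `Nc1nc2c(ncn2/C=C2\C[C@@H]2[C@H](O)CO)c(=O)[nH]1` carries a different base on the same scaffold; in this assay compound 2 likewise returns only a limit, > 300000 nM. Both measured compounds therefore sit at the same point: the limit of > 300000 nM in this assay, at which 2 of the 2 values shown sit. Going by the values given here, no step between two measured compounds with a numerical value can be stated, so no measured direction is available for this assay.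

Compound 3 `Nc1nc2c(ncn2/C=C2\C[C@H]2[C@@H](O)CO)c(=O)[nH]1` is not yet measured in this assay. Relative to compound 2 it shows (the two compounds have the same atoms and bonds and differ only in configuration as drawn: 2 of 3 stereo elements differ; a stereocentre at a saturated ring carbon is drawn S in compound 2 and R in compound 3; a stereocentre at a saturated chain carbon is drawn S in compound 2 and R in compound 3). Among the compounds with values here, no step between measured compounds is available, and the two measured values are both limits, so for the change from compound 2 to compound 3 no step beyond the scatter in this assay is expected. The expected step is a number no higher from compound 2 to compound 3 (the limit leaves the size open). Compound 3 is expected in this assay to give about 300000 nM, within 100000 nM to 1000000 nM, most likely again reported only as a limit.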

Compound 3, half-maximal cytotoxic concentration: 298000 nM
The estimate for compound 3 lay 1.0-fold (0.00 log units) above the measured number; the measured number falls inside the stated range.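

In this assay, going by these compounds alone, compound 3 gives 298000 nM, the first actual number rather than a limit. Within the data shown here, changing the configuration at the saturated ring carbon and the saturated chain carbon together gives a number no higher from compound 2 to compound 3 (the limit leaves the size open), and the only structural change behind this result is stereochemical: the fact that compounds 2 and 3 differ only in the configuration as drawn. The number for compound 3 stays close to the level at which the other readings stop: the limit of > 300000 nM in this assay, at which 2 of the 3 values shown sit.

The ring and chain stereocentres change together, so the contribution of each alone stays open, and the base of compound 1 is not shown with this inverted configuration. Also open, on these data alone, is whether a clearly lower number would appear with an amine or a carboxylic acid in place of a hydroxyl group on the chain.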